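Replacing a benzyl arm on a ring nitrogen with a benzoyl-type arm

A few compounds are considered here, and "the series" means these few. Any claim that something is new, unique, unknown or untested is made for them only; others in the source may bear on it.

Measured compounds:
- compound 1 `Cc1cc(C(=O)O)ccc1C(C)N1CCC[C@H](O[C@H](CO)c2cc(Cl)cc(Cl)c2)[C@@H]1c1ccccc1`: "nd" (no result reported) in an assay on isolated protein for activation of cGMP-dependent protein kinase 1 (Homo sapiens), read by ADP-Glo, with stated times of 30 min and 2 h; on this read-out lower numbers stand for an effect already at smaller amounts and higher numbers for an effect only at larger amounts of compound
- compound 2 `Nc1cc(C(=O)O)ccc1CN1CCC[C@H](O[C@H](CO)c2cc(Cl)cc(Cl)c2)[C@@H]1c1ccccc1`: 168000 nM

Two compounds share a core in which a six-membered ring with one nitrogen carries a phenyl group and a dichlorophenyl-bearing side chain. Compound 1 has no reported number. Among the measured compounds shown here, compound 2 is therefore the only compound with a value in this assay, and that value, 168000 nM, stands far toward the weak end of what such measurements usually report: an effect appears only at very large amounts of compound.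

Compound 3 `Cc1cc(C(=O)O)ccc1C(=O)N1CCC[C@H](O[C@H](CO)c2cc(Cl)cc(Cl)c2)[C@@H]1c1ccccc1` differs from compound 2 in one place: a group of 12 heavy atoms (9 carbon, 3 oxygen; one six-membered aromatic ring of carbon only) in place of a group of 11 heavy atoms (8 carbon, 1 nitrogen, 2 oxygen; one six-membered aromatic ring of carbon only), on an amine nitrogen in a ring. For the measured compounds named here, no step between two measured compounds is available to show what this kind of exchange does here.

With only the weak value of compound 2 as a foothold, compound 3 is expected to stay in the same weak region, with the step of a 1.2-fold higher number from compound 2 to compound 3 (0.08 log units; within the scatter) lying within the scatter of repeated measurements. The estimate for compound 3 is therefore 200000 nM, with a range from 50000 nM to 800000 nM.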

Compound 3, half-maximal effective concentration: > 200000 nM
Compound 3: only a limit was reported; the forecaster's own chance of this, stated with the estimate: 35%; the middle value lies on the limit itself.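

Compound 3 gives > 200000 nM in this assay, and this is a limit of the assay, not a number. The step is an at least 1.1-fold higher number from compound 2 to compound 3 (0.07 log units; that floor lies within the scatter), so placing a carbonyl-linked arm on the amine nitrogen in the ring, in place of the 2-amino-4-carboxybenzyl arm, gives no sign of a move toward smaller amounts of compound at this position. How far compound 3 really lies from compound 2 cannot be told, because the measurement ends at a limit: the limit of > 200000 nM in this assay, at which 1 of the 3 values shown sits.

The exchange also alters two things at once, the link to the nitrogen and the group on the aromatic ring, where a methyl takes the place of the amine, so the compounds shown cannot separate the part played by each. Still open, as far as these compounds go, are how an arm with the amine and a carbonyl link together would read out, and whether a longer chain between the ring nitrogen and the aromatic ring, or a tetrazole in place of the carboxylic acid, would bring the value into a range where differences can be measured.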